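Working notes: from compound 2 to compound 3

This account rests on a few compounds, and the source may have more. Where it says the series, first, only, none or still open, it means among the compounds named here.

Measured so far:
compound 1 `CC(=O)NC1=C(C#N)C(c2ccc(Cl)cc2)c2sc(Nc3ccc(S(N)(=O)=O)cc3)nc2O1` gives 41900 nM in a functional assay on MCF7 cells (Homo sapiens) for antiproliferative activity, read by sulforhodamine B assay, with a stated time of 48 h; on this read-out lower numbers stand for stronger inhibition and higher numbers for weaker inhibition
compound 2 `N#CC1=C(/N=C/c2ccccc2)Oc2nc(Nc3ccc(S(N)(=O)=O)cc3)sc2C1c1ccc(Cl)cc1` gives 45200 nM in this assay

Compound 2 carries the highest of the two numbers, yet its gap to compound 1 lies within the scatter. Compound 3 `N#CC1=C(NC(=O)CCl)Oc2nc(Nc3ccc(S(N)(=O)=O)cc3)sc2C1c1ccc(Cl)cc1` is not yet measured. The change is a group of 5 heavy atoms (2 carbon, 1 nitrogen, 1 oxygen, 1 chlorine; no ring) in place of a group of 8 heavy atoms (7 carbon, 1 nitrogen; one six-membered aromatic ring of carbon only), on a double-bonded ring carbon. Going by the values given here, the one measured step at this position, a 1.1-fold higher number from compound 1 to compound 2 (0.03 log units; within the scatter), showed no shift beyond the scatter, and the group entering in compound 3 is an acylamino group like that of compound 1. No step beyond the scatter is therefore expected in this assay. Compound 3 is estimated at 42000 nM, range 20000 nM to 90000 nM, meaning a 1.1-fold lower number from compound 2 to compound 3 (0.03 log units; within the scatter).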

Compound 3, half-maximal inhibitory concentration: 43800 nM
Beside the measured number, compound 3's estimate is 1.0-fold (0.02 log units) below it; the measured number falls inside the stated range.
By their numbers in this assay, from the lowest: compounds 1, 3 and 2 (each within the scatter of the next).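

At this double-bonded ring carbon, this assay gives a second step within the scatter, a 1.0-fold lower number from compound 2 to compound 3 (0.01 log units; within the scatter) when ((chloromethyl)carbonyl)amino replaces the group with the six-membered aromatic ring. Chloro in place of hydrogen on the saturated chain carbon bound to the carbonyl carbon also stays within the scatter, a 1.0-fold higher number from compound 1 to compound 3 (0.02 log units; within the scatter) being the step between the two acylamino groups. No measurement at hand bears on this result.

Going by these compounds, whether an amine, a carboxylic acid or a longer chain on this ring carbon would give a step beyond the scatter remains open.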